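The compounds below may be only part of what the source reports. "The series", "measured", "known", "first", "only" and "open" are said of these compounds alone.

Measured so far:
- compound 1, `COc1ccc(C(=O)c2sc(Nc3ccccc3)nc2N)cc1OC`: 6900 nM
- compound 2, `Cc1ccc(Nc2nc(-n3ccnc3C)cs2)cc1`: 1500 nM
- compound 3, `COc1cccc(Nc2nc(N)c(C(=O)c3ccccc3)s2)c1`: 2900 nM

These three compounds were tested in a functional assay on CCRF-CEM cells (Homo sapiens) for antiproliferative activity, read by cell counting, with a stated time of 2 days; on this read-out higher numbers stand for weaker inhibition and lower numbers for stronger inhibition. Compound 1 gives 6900 nM, the highest of the three numbers, so it is the weakest inhibitor here. Its nearest neighbour is compound 3 with 2900 nM, a gap that lies beyond the usual scatter, and compound 2 with 1500 nM sits furthest away, also beyond the scatter. No pair among these three differs in only one place, so no single structural step can be read off from them.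

Compound 4, `COc1cccc(C(=O)c2sc(Nc3ccccc3)nc2N)c1`, has not yet been measured. It differs from compound 1 in one spot: hydrogen in place of methoxy on an aromatic carbon. Because compound 1 stands at 6900 nM, and one of its two methoxy groups is simply removed, a small step is expected, most likely toward somewhat stronger inhibition, though it may well stay within the scatter. The expected step from compound 1 to compound 4 is a 1.4-fold lower number from compound 1 to compound 4 (0.14 log units; within the scatter). Compound 4 is thus estimated at 5000 nM, within a range from 1500 nM to 15000 nM.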

Compound 4, half-maximal inhibitory concentration: 2300 nM
Compound 4: the middle estimate sits 2.2-fold (0.34 log units) above what was measured, within the range that was stated.
By their numbers in this assay, from the lowest: compounds 2, 4 and 3 (each within the scatter of the next); then compound 1.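

In this assay, for the compounds shown here, removing one methoxy group and leaving hydrogen on that aromatic carbon gives a 3.0-fold lower number from compound 1 to compound 4 (0.48 log units; beyond the scatter) and provides the first comparison here between two compounds that differ in only one place. It shows that, in this pair, a methoxy group at this position, ortho to a methoxy group and para to a large group, is not needed for inhibition, and compound 4 without it is the stronger inhibitor. No measurement at hand explains this shift, so it stands as an observation only.

The compounds shown leave open whether the step depends on the methoxy group that remains in compound 4. They also leave open how a hydroxyl group, an amine or a fluorine atom at the same position would compare with hydrogen and methoxy.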